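Chloro to hydrogen on the sulfonyl aryl ring: solubility notes

The source may hold more compounds than are shown below. What is called first, only, known or untested is meant among the compounds shown, and "the series" means these compounds.

Compound 1 `CC(=O)NCc1cccc(Cn2nc(NS(=O)(=O)c3ccc(Cl)s3)c3ccccc32)c1` and compound 2 `CC(=O)NCc1cccc(Cn2nc(NS(=O)(=O)c3ccc(Cl)s3)c3c(Cl)cccc32)c1` share one core; compound 3 `COc1cccc2c1c(NS(=O)(=O)c1ccc(Cl)c(Cl)c1)nn2Cc1cccc(CNC(=O)C(C)(C)O)c1` and compound 4 `COc1cccc2c1c(NS(=O)(=O)c1cccc(Cl)c1)nn2Cc1cccc(CNC(=O)C(C)(C)O)c1` share another, and the difference between the two cores is not broken down here. In a physicochemical assay for solubility, read by chemiluminescence, measured as kinetic solubility (on this read-out lower numbers stand for lower solubility and higher numbers for higher solubility), compound 1 reads at a limit of the assay, >= 117 ug/mL. Compound 2 also reads at a limit of the assay, >= 226 ug/mL. Going by the values given here, compound 3 gives 76 ug/mL in this assay, the only plain number among the three. The change hydrogen in place of chloro on an aromatic carbon gives a step that the two limits leave unreadable from compound 2 to compound 1. Compound 4 carries the same kind of change, (hydrogen in place of chloro on an aromatic carbon), but the place differs: in compound 2 the carbon is part of a fused or bridged system of two rings, ortho to a fused ring and meta to a fused ring, whereas in compound 3 it is ortho to a chloro group and para to a large group. With the measured step unreadable, a modest step is expected, a 1.6-fold higher number from compound 3 to compound 4 (0.20 log units; within the scatter). Compound 4 is estimated at 120 ug/mL, between 50 ug/mL and 260 ug/mL.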

Compound 4, solubility: >= 198 ug/mL
Compound 4: only a limit was reported; the forecaster's own chance of this, stated with the estimate: 25%; at least 1.6-fold (0.21 log units) between middle value and limit.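

In this assay, the change from 3,4-dichlorophenyl to 3-chlorophenyl gives an at least 2.6-fold higher number from compound 3 to compound 4 (0.41 log units; beyond the scatter), so on this core hydrogen in place of chloro goes with a rise beyond the scatter. Going by these compounds, compound 4 reads at a limit of the assay, >= 198 ug/mL, so the full size of this step stays unknown. The step from compound 2 to compound 1 cannot be read, since both values are limits and the change sits at a different place, so carry-over between the two cores is neither supported nor excluded.

Still open, on these data alone, is how a plain value for compound 4 would compare. Also open, as far as these compounds go, is how an amine or a carboxylic acid would read in place of the chloro group on the 3-chlorophenyl ring.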